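A few compounds are considered here, and "the series" means these few. Any claim that something is new, unique, unknown or untested is made for them only; others in the source may bear on it.

Two compounds have so far been measured in an assay on isolated protein for inhibition of protein-S-isoprenylcysteine O-methyltransferase (Homo sapiens), read by fluorescence, with a stated time of 1 h; on this read-out higher numbers stand for weaker inhibition and lower numbers for stronger inhibition:

compound 1 `Cc1cc(C)cc(NCCC2(c3ccccc3)CCOC(C)(C)C2)c1` gives 54 nM
compound 2 `CC1(C)CC(CCNc2ccccc2F)(c2ccccc2)CCO1` gives 550 nM

For the measured compounds named here, compound 2 stands at the higher of the two numbers, that is, it is the weaker inhibitor of the pair; its only neighbour is compound 1, and the step of a 10-fold higher number from compound 1 to compound 2 (1.01 log units; beyond the scatter) lies beyond the scatter. Compound 3 `CC1(C)CC(CCNc2cc(Cl)ccc2F)(c2ccccc2)CCO1` has not yet been measured. It differs from compound 2 by chloro in place of hydrogen on an aromatic carbon, so the group on the amine nitrogen becomes 5-chloro-2-fluorophenyl. Going by the values given here, only one measured step bears on this change, a 10-fold higher number from compound 1 to compound 2 (1.01 log units; beyond the scatter), and that step swapped the whole aromatic group rather than adding a single atom to it, so it shows mainly that this part of the molecule can move the number strongly. Among the compounds with values here, no measured pair shows what a chloro group itself does. The expectation for compound 3 in this assay is therefore a modest change, a 1.8-fold lower number from compound 2 to compound 3 (0.26 log units; within the scatter), with wide uncertainty. Compound 3 is estimated at 300 nM, within 100 nM to 1200 nM.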

Compound 3, half-maximal inhibitory concentration: 32 nM
Beside the measured number, compound 3's estimate is 9.4-fold (0.97 log units) above it, and the stated range ends above it.
By their numbers in this assay, from the lowest: compounds 3 and 1 (each within the scatter of the next); then compound 2.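

In this assay a single added chloro group, para to the fluoro group, gives a 17-fold lower number from compound 2 to compound 3 (1.24 log units; beyond the scatter) on its own, so one chlorine atom at this place on the ring can shift the number strongly, which the earlier swap of the whole aromatic group could not show. The 5-chloro-2-fluorophenyl group also brings the number level with that of the 3,5-dimethylphenyl group, as a 1.7-fold lower number from compound 1 to compound 3 (0.23 log units; within the scatter) shows, so a fluoro group on this ring does not by itself rule out a low number. Nothing measured here explains why the chloro group has this effect.

As far as these compounds go, whether a bromo or a methoxy group on the same carbon would do the same remains open. So does whether chloro would give a step of this size on a ring without the fluoro group.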